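The compounds below may be only part of what the source reports. "The series", "measured", "known", "first", "only" and "open" are said of these compounds alone.

Compound 1, with the structure `CCCN1CCC(C(=O)Nc2cc(Cl)c(N)cc2OC)CC1`, is the starting point. In a functional assay on the whole organism for antagonist activity, with Mus musculus as the target (on this read-out lower numbers stand for an effect already at smaller amounts and higher numbers for an effect only at larger amounts of compound), compound 1 gives > 10 mg/kg, which is a limit of the assay rather than a measured number. Two close relatives carry other groups at the same place. Compound 2, `COc1cc(N)c(Cl)cc1NC(=O)C1CCN(Cc2ccc(C)c(C)c2)CC1`, has a 3,4-dimethylphenyl in place of ethyl on a saturated chain carbon bound to an amine nitrogen in a ring. In this assay compound 2 gives > 8 mg/kg, again only a limit. Compound 3, `COc1cc(N)c(Cl)cc1NC(=O)C1CCN(Cc2ccc(O)cc2)CC1`, has a 4-hydroxyphenyl at that same place. In this assay compound 3 gives > 8 mg/kg, also a limit. The step that the two limits leave unreadable from compound 1 to compound 2, the step that the two limits leave unreadable from compound 1 to compound 3 and the step that the two limits leave unreadable from compound 2 to compound 3 therefore cannot be read in size or direction; the evidence is only the limit of > 10 mg/kg in this assay, at which 1 of the 3 values shown sits, and (the limit of > 8 mg/kg in this assay, at which 2 of the 3 values shown sit).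

Compound 4, `COc1cc(N)c(Cl)cc1NC(=O)C1CCN(Cc2ccc(F)cc2)CC1`, differs from compound 1 as follows: 4-fluorophenyl in place of ethyl on a saturated chain carbon bound to an amine nitrogen in a ring. For the measured compounds named here, no measured step gives a readable size for a change of this kind at this place, so no shift beyond the scatter is expected, and the step that the limit leaves unreadable from compound 1 to compound 4 is an estimate resting on limits alone. Compound 4 is therefore expected to give about 12 mg/kg in this assay, with a likely range from 4 mg/kg to 40 mg/kg.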

Compound 4, dose for half-maximal effect: 0.6 mg/kg
Compound 4: middle estimate off by 20-fold (1.30 log units), on the high side, and the stated range ends above it.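

Replacing ethyl with 4-fluorophenyl on a saturated chain carbon bound to an amine nitrogen in a ring gives the first readable effect in this assay, with an at least 16-fold lower number from compound 1 to compound 4 (1.22 log units; beyond the scatter). An aromatic ring at this place does not bring the effect on its own, and the groups on that ring matter: fluoro in place of hydroxy on an aromatic carbon gives an at least 13-fold lower number from compound 3 to compound 4 (1.12 log units; beyond the scatter), and 4-fluorophenyl in place of 3,4-dimethylphenyl gives an at least 13-fold lower number from compound 2 to compound 4 (1.12 log units; beyond the scatter). Each of these steps starts from a limit of the assay rather than a measured number, so the real gain could be larger, and the steps among compound 1, compound 2 and compound 3 cannot be read at all: the limit of > 10 mg/kg in this assay, at which 1 of the 4 values shown sits, and the limit of > 8 mg/kg in this assay, at which 2 of the 4 values shown sit.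

The compounds shown leave open whether fluorine itself is needed, since a plain benzyl, a 4-chlorobenzyl or a 4-methoxybenzyl at this place could show whether other groups also give a low number. They also leave open whether the 4-fluorophenyl keeps its effect on a longer chain, as in a 4-fluorophenethyl group.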